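A few compounds are considered here, and "the series" means these few. Any claim that something is new, unique, unknown or untested is made for them only; others in the source may bear on it.

Compound 1 `CN(c1cccc2c1CCCC2c1c[nH]cn1)S(C)(=O)=O` and compound 2 `CN(C)S(=O)(=O)Nc1cccc2c1CCCC2c1c[nH]cn1` share one core. In an assay on isolated protein (Cricetulus griseus) for binding affinity to Alpha-1B adrenergic receptor (Mesocricetus auratus), read by radioligand binding (on this read-out higher numbers stand for weaker inhibition and lower numbers for stronger inhibition), compound 1 gives < 10000 nM, which is a limit of the assay and not a number. In this assay compound 2 likewise gives < 10000 nM, again a limit rather than a number. The step that the two limits leave unreadable from compound 1 to compound 2 cannot be read because of the limit of < 10000 nM in this assay, at which 2 of the 2 values shown sit. Compound 3 `COC(=O)Nc1cccc2c1CCCC2c1c[nH]cn1` carries methoxycarbonyl in place of dimethylsulfamoyl on a nitrogen on an aromatic ring. Among the compounds with values here, with no measured step readable, compound 3 is expected to show a step that the limit leaves unreadable from compound 2 to compound 3 that is only loosely anchored. Compound 3 is estimated at 2000 nM, with a range from 200 nM to 10000 nM.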

Compound 3, inhibition constant: 10000 nM
The estimate for compound 3 lay 5.0-fold (0.70 log units) below the measured number; the range from low to high includes it.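

In this assay, within the data shown here, compound 3 gives 10000 nM, the first actual number among the compounds carrying a group on this nitrogen on an aromatic ring, which makes a number no lower from compound 2 to compound 3 (the limit leaves the size open) and a number no lower from compound 1 to compound 3 (the limit leaves the size open). With methoxycarbonyl there, the read-out reaches a value rather than a limit. The size of neither step to compound 3 can be read, because the other two values are limits: the limit of < 10000 nM in this assay, at which 2 of the 3 values shown sit.

On these data alone, how far compound 1 and compound 2 lie from compound 3 remains open. So does what an acetyl group or a longer alkoxycarbonyl chain on this nitrogen would give.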